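Chloro on the pendant phenyl: notes toward compound 4

The compounds below may be only part of what the source reports. "The series", "measured", "known", "first", "only" and "open" are said of these compounds alone.

Compound 1 `Cc1nc(-c2ccccc2)sc1C(=O)CSc1nc(-c2ccc(Cl)c(Cl)c2)c(C#N)c(=O)[nH]1` gives 65000 nM in a functional assay on U-87MG ATCC cells for antiproliferative activity against U-87 MG (Homo sapiens), read by MTT assay, with a stated time of 48 h; a lower number here means a stronger inhibitor, a higher number a weaker inhibitor; compound 2 `Cc1nc(-c2ccccc2)sc1C(=O)CSc1nc(-c2cccc(Cl)c2)c(C#N)c(=O)[nH]1` gives 28200 nM; compound 3 `COc1ccc(-c2nc(C)c(C(=O)CSc3nc(-c4ccccc4)c(C#N)c(=O)[nH]3)s2)cc1` gives 57300 nM. The change chloro in place of hydrogen on an aromatic carbon made the step of a 2.3-fold higher number from compound 2 to compound 1 (0.36 log units; beyond the scatter). The difference between the cores of compound 2 and compound 3 is not broken down here. Compound 4 `COc1ccc(-c2nc(C)c(C(=O)CSc3nc(-c4cccc(Cl)c4)c(C#N)c(=O)[nH]3)s2)cc1` is not yet measured; it differs from compound 3 by chloro in place of hydrogen on an aromatic carbon. Among the compounds with values here, this is the same kind of change as the one from compound 2 to compound 1, not the same: there the entering chloro stood ortho to a chloro group and para to a large group, here it stands meta to a large group. Within the data shown here, only one measured step of this kind exists, and it was modest, so the step expected in this assay is a 1.4-fold lower number from compound 3 to compound 4 (0.13 log units; within the scatter), resting on a 2.3-fold higher number from compound 2 to compound 1 (0.36 log units; beyond the scatter). Compound 4 is therefore estimated at 42000 nM, between 15000 nM and 110000 nM.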

Compound 4, half-maximal inhibitory concentration: 78900 nM
For compound 4 the middle estimate is 1.9-fold (0.27 log units) below the measured one; the measured number falls inside the stated range.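

In this assay the chloro change read on a second core gives a 1.4-fold higher number from compound 3 to compound 4 (0.14 log units; within the scatter), and the two readings of this change cannot be told apart: the same change on two cores in this assay, a 2.3-fold higher number (0.36 log units; beyond the scatter) from compound 2 to compound 1 and a 1.4-fold higher number (0.14 log units; within the scatter) from compound 3 to compound 4, 1.7-fold (0.22 log units) apart, within the scatter of two such steps

This shows no measurable dependence on the core across these two pairs, but two pairs do not establish that the change carries over generally, and the chlorine enters at a different place in each, so the comparison is not of a single position. Methoxy in place of hydrogen gives a 2.8-fold higher number from compound 2 to compound 4 (0.45 log units; beyond the scatter), a single step with no second reading to set beside it.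

The compounds shown leave open whether an amine or a carboxylic acid on the same phenyl ring would shift the number more than chloro or methoxy do.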